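Series notes: chloropurine glycinamide esters in the tail flick test

The compounds below may be only part of what the source reports. "The series", "measured", "known", "first", "only" and "open" are said of these compounds alone.

Compound 2 `CC(C)[C@H](NC(=O)CN(c1nc(Cl)nc2[nH]cnc12)C1CC1)C(=O)OCc1ccccc1` gives 51.3% in a functional assay on the whole organism (Tail, strain ICR) with Mus musculus as the target, in the tail flick test, with a stated time of 90 min, at a dose of 25 umol/kg by the oral route (on this read-out higher numbers stand for a stronger effect at the one dose given and lower numbers for a weaker effect), and stands highest of the three numbers measured. Compound 1 `NC(=O)CC[C@H](NC(=O)CN(c1ncnc2c1ncn2C1CCCCO1)C1CC1)C(=O)OCc1ccccc1` gives 37.8% in this assay, a number beyond the scatter below compound 2. Compound 3 `NC(=O)C[C@H](NC(=O)CN(c1nc(Cl)nc2[nH]cnc12)C1CC1)C(=O)O` gives 20.1% in this assay, the lowest of the three and also beyond the scatter below compound 2. Going by the values given here, no pair of these three differs in a single place, so no measured step is available.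

Compound 4 `NCCCC[C@H](NC(=O)CN(c1nc(Cl)nc2[nH]cnc12)C1CC1)C(=O)OCc1ccccc1` is not yet measured. It differs from compound 2 as follows: 4-aminobutyl in place of isopropyl on a saturated chain carbon bound to an amide-type nitrogen and a carbonyl carbon. Among the compounds with values here, with no comparable step measured, a downward step of moderate size is expected in this assay, though the uncertainty is wide enough to include no change beyond the scatter. For compound 4 the expected value is 38%, with a range from 18% to 58%, which corresponds to an expected step of a number 13.3 percentage points lower from compound 2 to compound 4 (beyond the scatter).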

Compound 4, a percentage reported as activity, at one dose (the size of the read-out at that dose, not a potency): 35.3%
Estimate against measurement, compound 4: 2.7 percentage points above; the range from low to high includes it.
By their numbers in this assay, from the lowest: compound 3; then compounds 4 and 1 (each within the scatter of the next); then compound 2.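

Putting 4-aminobutyl in place of isopropyl on a saturated chain carbon bound to an amide-type nitrogen and a carbonyl carbon gives a number 16 percentage points lower from compound 2 to compound 4 (beyond the scatter) in this assay. Going by these compounds alone, this is the first step read at this position, and it shows that the effect at the one dose given depends on the group carried there, with a modest drop for this change. No measurement bearing on the cause of this step is available.

From the compounds shown here alone, whether the drop follows the longer chain or its terminal amine remains open. A plain butyl chain or a terminal carboxylic acid at this position would help separate the two.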